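A few compounds are considered here, and "the series" means these few. Any claim that something is new, unique, unknown or untested is made for them only; others in the source may bear on it.

Compound 3 `CCCCCNC(=O)CC1CCc2cc(OC)c(OC)cc21` gives 35.2% in a functional assay on the whole organism (strain Wistar) for inhibition, with Rattus norvegicus as the target, read by paw edema, with stated times of 60 min and 6 h, at a dose of 100 mg/kg by the oral route (a higher number here means more inhibition at the dose given (going by the name of the read-out), a lower number less inhibition), the highest of the three numbers shown, though only the gap to compound 2 lies beyond the scatter. Compound 1 `CCN(CC)C(=O)CC1CCc2cc(OC)c(OC)cc21` gives 31.5% in this assay, and compound 2 `CCCNC(=O)CC1CCc2cc(OC)c(OC)cc21` gives 22.2%. The step of a number 3.7 percentage points higher from compound 1 to compound 3 (within the scatter) stays within the scatter; the step of a number 13 percentage points higher from compound 2 to compound 3 (beyond the scatter) reaches beyond it. Compound 4 `COc1cc2c(cc1OC)C(CC(=O)NC1CCCC1)CC2` differs from compound 3 by cyclopentyl in place of pentyl on an amide-type nitrogen. Within the data shown here, no measured step exchanges an open chain for a ring on the amide-type nitrogen; the steps of a number 9.3 percentage points lower from compound 1 to compound 2 (within the scatter) and a number 3.7 percentage points higher from compound 1 to compound 3 (within the scatter) show exchanges of substituents of similar size on that nitrogen remaining within the scatter. Compound 4 is therefore expected to give about 34%, with a range from 22% to 47%. The expected step is a number 1.2 percentage points lower from compound 3 to compound 4 (within the scatter), within the scatter.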

Compound 4, a percentage reported as inhibition, in the whole organism at one dose (the size of the read-out at that dose, not a potency): 40.7%
Estimate against measurement, compound 4: 6.7 percentage points below, within the range that was stated.
By their numbers in this assay, from the lowest: compounds 2, 1, 3 and 4 (each within the scatter of the next, the first and the last beyond it).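

Cyclopentyl on the amide-type nitrogen is the first ring at this position, and in this assay it holds the level of the open chain, with a number 5.5 percentage points higher from compound 3 to compound 4 (within the scatter). Against the shorter and branched amides the ring gives a number 18.5 percentage points higher from compound 2 to compound 4 (beyond the scatter) and a number 9.2 percentage points higher from compound 1 to compound 4 (within the scatter), so only the propyl amide compound 2 stands apart. Nothing available explains how the ring and the open chains compare at this nitrogen.

On these data alone, whether a cyclohexyl or a phenyl on the same nitrogen would keep this level remains open. So does the effect of a hydroxyl on the cyclopentyl ring.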